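Enaminone series on prostate carcinoma cells: next variation

A few compounds are considered here, and "the series" means these few. Any claim that something is new, unique, unknown or untested is made for them only; others in the source may bear on it.

Measured compounds:
compound 1 `O=C(/C=C\Nc1ccc(F)cc1)c1cn(-c2ccccc2)nc1-c1ccccc1` — 7980 nM
compound 2 `O=C(/C=C\Nc1ccc(F)cc1)c1cn(-c2ccccc2)nc1-c1ccc(F)cc1` — 7900 nM
compound 3 `COc1ccc(-c2nn(-c3ccccc3)cc2C(=O)/C=C\Nc2ccc(F)cc2)cc1` — 5730 nM

In a functional assay on PC-3 cells (Homo sapiens) for antiproliferative activity, read by MTT assay, with a stated time of 48 h (on this read-out higher numbers stand for weaker inhibition and lower numbers for stronger inhibition), compound 3 carries the lowest of the three numbers, yet a 1.4-fold lower number from compound 1 to compound 3 (0.14 log units; within the scatter) and a 1.4-fold lower number from compound 2 to compound 3 (0.14 log units; within the scatter) are both within the scatter, as is a 1.0-fold lower number from compound 1 to compound 2 (0.00 log units; within the scatter). Compound 4 `COc1ccc(-c2nn(-c3ccccc3)cc2C(=O)/C=C\Nc2cc(OC)c(OC)c(OC)c2)cc1` differs from compound 3 by 3,4,5-trimethoxyphenyl in place of 4-fluorophenyl on an amine nitrogen. Going by the values given here, none of the measured steps touches that nitrogen: all three vary the other aryl ring, and all fall within the scatter. Among the compounds with values here, no measured step therefore bears on this change, and a step of no more than the scatter in this assay is expected, with wide uncertainty. Compound 4 is estimated at 4000 nM, range 800 nM to 20000 nM, meaning a 1.4-fold lower number from compound 3 to compound 4 (0.16 log units; within the scatter) as the expected step.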

Compound 4, half-maximal inhibitory concentration: 18900 nM
Compound 4: middle estimate off by 4.7-fold (0.67 log units), on the low side; the range from low to high includes it.
By their numbers in this assay, from the lowest: compounds 3, 2 and 1 (each within the scatter of the next); then compound 4.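

The aryl group on the amine nitrogen is the only varied position shown where a change exceeds the scatter: in this assay, 3,4,5-trimethoxyphenyl in place of 4-fluorophenyl gives a 3.3-fold higher number from compound 3 to compound 4 (0.52 log units; beyond the scatter). The step is modest, but it points to weaker inhibition and shows more sensitivity to this one change than the steps on the other aryl ring showed. Nothing available explains the shift.

Still open, on these data alone, is whether a single methoxy group, as in 4-methoxyphenyl on that nitrogen, would shift the number similarly. Unsubstituted phenyl or 4-chlorophenyl there would also test whether 4-fluorophenyl itself matters.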